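The source may report more compounds than this note shows. Statements on the series, on what has been measured and on what is new or still open speak of the compounds shown alone.

Working notes on the series in a functional assay on HL-60 cells (Homo sapiens) for cytotoxicity, read by CellTiter-Blue, with a stated time of 48 h; a lower number here means a stronger inhibitor, a higher number a weaker inhibitor:

- compound 1 `CCCOC(=O)CC1C(C(=O)OCCC)=C(N)Oc2ccc(-c3cc(OC)cc(OC)c3)cc21`: 7600 nM
- compound 2 `C=CCOC(=O)CC1C(C(=O)OCC=C)=C(N)Oc2ccc(-c3cc(OC)cc(OC)c3)cc21`: 4700 nM
- compound 3 `CCOC(=O)CC1C(C(=O)OCC)=C(N)Oc2ccc(-c3ccco3)cc21`: > 80000 nM

Compound 1 gives 7600 nM and compound 2 gives 4700 nM, values within the usual scatter of each other. Compound 3 stands at > 80000 nM, which is a limit of the assay and not a number.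

Compound 4 `CCOC(=O)CC1C(C(=O)OCC)=C(N)Oc2ccc(-c3ccnc(OC)c3)cc21` carries 2-methoxypyridin-4-yl in place of furan-2-yl on an aromatic carbon of a six-membered aromatic ring of carbon only (2-methoxypyridin-4-yl in place of furan-2-yl on an aromatic carbon). Among the measured compounds shown here, no step between compounds differing in one place has been measured in this assay, so any expectation here is loose. Compound 1, at 7600 nM, also holds a methoxy-bearing six-membered aromatic ring at that place. This points to a lower number for compound 4 than the limit of compound 3, though probably not as low as compound 1. The expected change is a moderate gain in strength, estimated as an at least 4.0-fold lower number from compound 3 to compound 4 (0.60 log units; beyond the scatter). For compound 4 the estimated value is 20000 nM, with an expected range of 6000 nM to 70000 nM.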

Compound 4, half-maximal inhibitory concentration: 10200 nM
For compound 4 the middle estimate is 2.0-fold (0.29 log units) above the measured one, within the range that was stated.
By their numbers in this assay, from the lowest: compounds 2, 1 and 4 (each within the scatter of the next, the first and the last beyond it). At a limit, above all of these: compound 3.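

In this assay, the place on an aromatic carbon of the six-membered aromatic ring of carbon only now has its first readable step: 2-methoxypyridin-4-yl in place of furan-2-yl gives an at least 7.8-fold lower number from compound 3 to compound 4 (0.89 log units; beyond the scatter). Among the compounds shown here, the earlier compounds held no pair differing in one place, so this is the first sign that the group here moves the number while the rest of the molecule stays the same. The step is a bound and not a full size, because compound 3 rests at a limit of the assay: the limit of > 80000 nM in this assay, at which 1 of the 4 values shown sits.

Open, on these data alone, is which part of 2-methoxypyridin-4-yl carries the step: the ring nitrogen, the methoxy or the six-membered ring itself. A plain phenyl or a pyridin-4-yl without the methoxy at this place would separate these, and an amine in place of the methoxy would test that group directly.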